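This account rests on a few compounds, and the source may have more. Where it says the series, first, only, none or still open, it means among the compounds named here.

Measured in an in vitro ADME assay on microsomes from liver (Mus musculus) for pharmacokinetics, read by LC-MS, with a stated time of 10 min, tested at 1 uM; on this read-out higher numbers stand for fast clearance and lower numbers for slow clearance:
compound 1, `Cc1ccc(NC(=O)[C@H]2CN(C)C[C@@H]2c2ccc(/C=C/C(=O)Nc3ccccc3N)cc2)cc1`: 62 mL/min/kg
compound 2, `CN1C[C@H](C(=O)Nc2cccc(Cl)c2)[C@@H](c2ccc(/C=C/C(=O)Nc3ccccc3N)cc2)C1`: 58 mL/min/kg

Compound 2 gives the lower of the two values in this assay; its nearest neighbour is compound 1, and the step of a 1.1-fold lower number from compound 1 to compound 2 (0.03 log units; within the scatter) lies within the scatter. Compound 3, `CN1C[C@H](C(=O)NC2CC2)[C@@H](c2ccc(/C=C/C(=O)Nc3ccccc3N)cc2)C1`, is not yet measured. It differs from compound 2 by cyclopropyl in place of 3-chlorophenyl on an amide-type nitrogen. Within the data shown here, the one measured step at this amide-type nitrogen, a 1.1-fold lower number from compound 1 to compound 2 (0.03 log units; within the scatter), did not move the number beyond the scatter, so for compound 3 no step beyond the scatter in either direction is expected, an estimate of a 1.1-fold lower number from compound 2 to compound 3 (0.02 log units; within the scatter). Compound 3 is expected at about 55 mL/min/kg, within 30 mL/min/kg to 95 mL/min/kg.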

Compound 3, clearance: 7 mL/min/kg
The estimate for compound 3 lay 7.9-fold (0.90 log units) above the measured number; measured number outside the range, below it.
By their numbers in this assay, from the lowest: compound 3; then compounds 2 and 1 (each within the scatter of the next).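

In this assay, the amide-type nitrogen proves sensitive to the group it carries: cyclopropyl lowers the clearance relative to both 3-chlorophenyl (an 8.3-fold lower number from compound 2 to compound 3 (0.92 log units; beyond the scatter)) and 4-methylphenyl (an 8.9-fold lower number from compound 1 to compound 3 (0.95 log units; beyond the scatter)). The exchange between the two substituted phenyl groups had stayed within the scatter, so only the change from a phenyl group to cyclopropyl reveals this sensitivity. No measurement at hand accounts for the difference.

From the compounds shown here alone, it remains open whether the low clearance is specific to cyclopropyl. An open-chain ethyl group or a cyclohexyl ring on this nitrogen would test that.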